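Replacing a nitro group with acetamido on a shared pyrimidine ether

This account rests on a few compounds, and the source may have more. Where it says the series, first, only, none or still open, it means among the compounds named here.

Compound 1 `Cc1cc(C#N)cc(C)c1Oc1ccnc(Nc2ccc(C#N)cc2)n1`: 1.64
Compound 2 `Cc1cc(C#N)cc(C)c1Oc1nc(Nc2ccc(C#N)cc2)ncc1[N+](=O)[O-]`: -0.98

In a physicochemical assay for lipophilicity (on this read-out higher numbers stand for higher lipophilicity and lower numbers for lower lipophilicity), compound 2 gives the lower of the two numbers, and compound 1 the higher. Among the measured compounds shown here, the step from hydrogen to nitro, a number 2.62 log units lower from compound 1 to compound 2 (beyond the scatter), is the only measured change that bears on the next one. Compound 3 `CC(=O)Nc1cnc(Nc2ccc(C#N)cc2)nc1Oc1c(C)cc(C#N)cc1C` differs from compound 2 by acetamido in place of nitro on an aromatic carbon. For the measured compounds named here, no measured step shows acetamido in place of nitro, so the direction is uncertain; a modest rise or no step beyond the scatter is expected, a number 0.38 log units higher from compound 2 to compound 3 (beyond the scatter). For compound 3 the estimate in this assay is -0.6, within -1.9 to 0.7.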

Compound 3, partition coefficient: -0.12
Compound 3: middle estimate off by 0.48 log units, on the low side; the measured number falls inside the stated range.
By their numbers in this assay, from the lowest: compound 2; then compound 3; then compound 1.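

In this assay the new result shows that the drop at this aromatic carbon depends on the group placed there. Acetamido in place of nitro recovers only part of that drop (a number 0.86 log units higher from compound 2 to compound 3 (beyond the scatter)), while acetamido in place of hydrogen still leaves a large fall (a number 1.76 log units lower from compound 1 to compound 3 (beyond the scatter)). Nothing measured here explains why these groups differ.

Where an amine or a carboxylic acid on this same carbon would fall relative to these three compounds remains open. So does whether this order would hold on a different core.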